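The source may hold more compounds than are shown below. What is called first, only, known or untested is meant among the compounds shown, and "the series" means these compounds.

Measured so far:
- compound 1, `CC(C)n1cc(-c2ccnc3[nH]c(C4CCN(CC(=O)N5CCCC5)CC4)cc23)ccc1=O`: in a physicochemical assay for acid dissociation, compound 1 gives 7.8
- compound 2, `COc1cc(C(=O)N2CCCC2)ccc1-c1ccnc2[nH]c(C3CCNCC3)cc12`: in this assay compound 2 gives 10.2

Of these two numbers, compound 1 holds the lower one. Its nearest neighbour is compound 2, and the gap between them is beyond the usual scatter of the measurement, so the two compounds are genuinely different in this assay.

The next compound, compound 3, `CNC(=O)CN1CCC(c2cc3c(-c4ccc(=O)n(C(C)C)c4)ccnc3[nH]2)CC1`, is not yet measured. It comes from compound 1 by a single change at the end of the chain that hangs from the piperidine ring: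

methylamino in place of pyrrolidin-1-yl on a carbonyl carbon

In this change, the pyrrolidin-1-yl group leaves a carbonyl carbon whose other neighbour is a saturated chain carbon, and methylamino enters in the same place. Going by the values given here, the group that changes is several bonds away from the ring nitrogen, and no measured pair here shows what such a change does. The expectation is therefore that the step from compound 1 to compound 3 in this assay is small and in no clear direction: a number 0.10 log units lower from compound 1 to compound 3 (within the scatter) is expected to stay within the scatter. Compound 3 is thus estimated at 7.7, with a range from 7.2 to 8.2.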

Compound 3, acid dissociation constant: 6.9
Beside the measured number, compound 3's estimate is 0.80 log units above it; measured number outside the range, below it.
By their numbers in this assay, from the lowest: compound 3; then compound 1; then compound 2.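

The end of the chain hanging from the piperidine ring turns out not to be a silent place: in this assay, putting methylamino in place of pyrrolidin-1-yl on a carbonyl carbon gives a number 0.90 log units lower from compound 1 to compound 3 (beyond the scatter), so a change on this carbonyl carbon, whose other neighbour is a saturated chain carbon, can move this number. The earlier compounds shown here could not show this, since compound 1 and compound 2 differ in more than one place and gave no single step to read. The change itself does several things at once, going from 5 heavy atoms in a five-membered ring to 2 heavy atoms with no ring and adding 1 hydrogen-bond donor, and nothing measured here links the step to any one of these differences.

The compounds shown leave open which of those differences goes with the lower number. Dimethylamino on the same carbonyl carbon would have no ring and no amide hydrogen, while azetidin-1-yl would keep a ring with fewer atoms, so either group would help to separate these differences.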